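Methoxy for phenyl on the aryl ketone of compound 2

The source may report more compounds than this note shows. Statements on the series, on what has been measured and on what is new or still open speak of the compounds shown alone.

Of the compounds shown here, two have numbers so far. Compound 1 `CC(=O)c1ccc(Nc2ccnc(SCC(=O)c3ccc(Br)cc3)n2)cc1` carries a bromo group on the aryl ketone and, in a functional assay on CCRF-CEM cells (Homo sapiens) for inhibition, read by sulforhodamine B assay, with a stated time of 48 h, tested at 10 uM (on this read-out lower numbers stand for less inhibition of growth and higher numbers for more inhibition of growth at the one concentration tested), compound 1 gives 30%. Compound 2 `CC(=O)c1cccc(Nc2ccnc(SCC(=O)c3ccc(-c4ccccc4)cc3)n2)c1` carries a phenyl group at the same position and a meta-positioned acetyl on the aniline; in this assay compound 2 gives 28%, which lies within the scatter of the number for compound 1. On the numbers shown, compound 2 therefore stands level with the only other measured compound; no step beyond the scatter has been recorded between the two.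

Compound 3 `COc1ccc(C(=O)CSc2nccc(Nc3cccc(C(C)=O)c3)n2)cc1` differs from compound 2 in one place: methoxy in place of phenyl on an aromatic carbon. Going by the values given here, no measured pair tells what this exchange does, so the expectation can only rest on the two numbers available, which show two different groups at this position giving near-identical inhibition. For compound 3 no step beyond the scatter is expected in this assay, in either direction, and the estimated step is a number 1 percentage points lower from compound 2 to compound 3 (within the scatter). Compound 3 is expected to give about 27% in this assay, with a range from 12% to 42%.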

Compound 3, percent growth inhibition at one concentration: 46%
Beside the measured number, compound 3's estimate is 19 percentage points below it, and the stated range ends below it.
By their numbers in this assay, from the lowest: compounds 2 and 1 (each within the scatter of the next); then compound 3.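

In this assay, going by these compounds alone, methoxy in place of phenyl gives a number 18 percentage points higher from compound 2 to compound 3 (beyond the scatter), the first step that can be read across a change in one place, so the group on this aromatic carbon, para to a large group, does affect growth inhibition. The exchange alters several things at once: a six-membered aromatic ring of carbon only leaves, and a group of 2 heavy atoms with 1 hydrogen-bond acceptor enters, and this single step cannot assign the gain to any one of these differences. Nothing available here accounts for the step.

Open, on these data alone, is whether the gain follows the loss of the ring or the arrival of the oxygen, which an ethyl group, with no oxygen, or an ethoxy group, a longer ether chain, at the same carbon would help to separate. Also open, as far as these compounds go, is whether the same exchange gives a comparable step on the core of compound 1, where the acetyl sits elsewhere on the aniline ring.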